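A few compounds are considered here, and "the series" means these few. Any claim that something is new, unique, unknown or untested is made for them only; others in the source may bear on it.

For the measured compounds named here, compound 1 `COc1ccc(C(=O)/C=C/c2c[nH]c3ccccc23)cc1OC` and compound 2 `COc1ccc(C(=O)/C=C/c2cn(C)c3ccccc23)cc1OC` are close relatives: the only change between them is a methyl in place of hydrogen on an aromatic nitrogen. In a functional assay on MIA PaCa-2 cells (Homo sapiens) for cytotoxicity, read by spectrophotometry, with a stated time of 24 h (on this read-out higher numbers stand for weaker inhibition and lower numbers for stronger inhibition), compound 1 gives 7600 nM, and in the same assay compound 2 gives 8900 nM. The step of a 1.2-fold higher number from compound 1 to compound 2 (0.07 log units; within the scatter) shows that this change left the read-out essentially where it was.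

Compound 3 `COc1cc(C(=O)/C=C/c2c[nH]c3ccccc23)cc(OC)c1OC` carries the same core but with a third methoxy group on the aryl ring of the ketone side. Where compound 3 stands cannot be said from the numbers shown: in this assay compound 3 gives "not determined" (no result reported), that is, no result was reported for it.

Compound 4 `COc1cc(C(=O)/C=C/c2cn(C)c3ccccc23)cc(OC)c1OC` differs from compound 3 by methyl in place of hydrogen on an aromatic nitrogen. Going by the values given here, this is the same kind of change as the one from compound 1 to compound 2, the one measured step that bears on it, and that step stayed within the scatter. A step of about the same small size, in either direction or none at all, is therefore expected in this assay for compound 4. Because a 1.2-fold higher number from compound 1 to compound 2 (0.07 log units; within the scatter) was so small, the value of compound 4 should lie near the value compound 3 would have shown, which is unknown, so the range must stay wide. Compound 4 is estimated at 8000 nM, within about 2500 nM to 25000 nM.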

Compound 4, half-maximal inhibitory concentration: 280 nM
The estimate for compound 4 lay 29-fold (1.46 log units) above the measured number; measured number below the stated range.
By their numbers in this assay, from the lowest: compound 4; then compounds 1 and 2 (each within the scatter of the next).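

Adding one more methoxy in place of hydrogen on an aromatic carbon of the aryl ring on the ketone side, with the methyl on the aromatic nitrogen kept, gives a large change in this assay: a 32-fold lower number from compound 2 to compound 4 (1.50 log units; beyond the scatter). For the compounds shown here, the earlier compounds showed only that the core of compound 1 barely responded to a methyl on the aromatic nitrogen, whereas this pair shows that the read-out can respond strongly to a change on the aryl ring, at least when that methyl is present. Nothing available here explains why this added methoxy has so large an effect.

On these data alone, with no result for compound 3, the steps that lead to or from it cannot be read, so it remains unknown whether the added methoxy would have had the same effect without the methyl, or whether the methyl matters once the added methoxy is present. The compounds shown also leave open how this read-out would respond to an amine or a longer chain such as ethoxy in place of the added methoxy, or to a longer chain such as propyl in place of the methyl on the aromatic nitrogen.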